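Shifting a trifluoromethyl group: what cytotoxicity to expect

The source may hold more compounds than are shown below. What is called first, only, known or untested is meant among the compounds shown, and "the series" means these compounds.

Measured in an ADME assay on HEK-293T cells (Homo sapiens) for cytotoxicity, read by MTT assay, with a stated time of 3 days; on this read-out lower numbers stand for higher toxicity in this test and higher numbers for lower toxicity in this test:
Compound 1 `CC(=O)Oc1ccc(CN(C(=O)COC(=O)c2ccc([N+](=O)[O-])o2)C(C)(C)C)cc1`: > 100000 nM (a limit of the assay, not a number)
Compound 2 `CC(C)(C)N(Cc1cccc(C(F)(F)F)c1)C(=O)COC(=O)c1ccc([N+](=O)[O-])o1`: 68000 nM

Among the measured compounds shown here, compound 2, at 68000 nM, holds the only exact number in this assay. Compound 3 `CC(C)(C)N(Cc1ccccc1C(F)(F)F)C(=O)COC(=O)c1ccc([N+](=O)[O-])o1` has the same atoms, joined differently: 2-(trifluoromethyl)phenyl in place of 3-(trifluoromethyl)phenyl on a saturated chain carbon bound to an amide-type nitrogen. For the measured compounds named here, only one measured step bears on this, an at least 1.4-fold lower number from compound 1 to compound 2 (0.16 log units; that floor lies within the scatter), and it changed the group at the same place. With so little evidence and such a small structural change, no shift beyond the scatter is expected. The expected step is a 1.1-fold lower number from compound 2 to compound 3 (0.05 log units; within the scatter). For compound 3 the estimated value is 60000 nM, with an expected range from 25000 nM to 100000 nM.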

Compound 3, half-maximal cytotoxic concentration: 65000 nM
Estimate against measurement, compound 3: 1.1-fold (0.03 log units) below; low and high end bracket the measured number.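

In this assay the new step is a 1.0-fold lower number from compound 2 to compound 3 (0.02 log units; within the scatter) and so shows that, on a saturated chain carbon bound to an amide-type nitrogen, 2-(trifluoromethyl)phenyl and 3-(trifluoromethyl)phenyl cannot be told apart. The comparison with 4-acetoxyphenyl gives an at least 1.5-fold lower number from compound 1 to compound 3 (0.18 log units; that floor lies within the scatter) and remains only a floor, with no true size. Compound 1 stands at a limit, not a number: the limit of > 100000 nM in this assay, at which 1 of the 3 values shown sits.

On these data alone, what stays open is whether an amine or a carboxylic acid on the phenyl ring, in place of trifluoromethyl, would move the number beyond the scatter.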